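This account rests on a few compounds, and the source may have more. Where it says the series, first, only, none or still open, it means among the compounds named here.

Measured compounds in a functional assay on cells for agonist activity at Free fatty acid receptor 1 (Homo sapiens), read by calcium flux; on this read-out lower numbers stand for an effect already at smaller amounts and higher numbers for an effect only at larger amounts of compound:
- compound 1, `COC(CC(=O)O)c1ccc(OCc2cccc(-c3c(C)cccc3C)c2)s1`: 210 nM
- compound 2, `Cc1cccc(C)c1-c1cccc(OCc2cn(CCC(=O)O)nn2)c1`: 14700 nM
- compound 3, `Cc1cccc(C)c1-c1cccc(OCn2cc(CCC(=O)O)nn2)c1`: 32200 nM

Of the three numbers in this assay, compound 1 gives the lowest; compound 2 gives a number much higher than that of compound 1, and compound 3 a number higher still. Both gaps from compound 1 lie well beyond the scatter, so compound 1 is the most potent of the three as measured. Among the compounds with values here, compounds 2 and 3 keep the dimethylphenyl-bearing end but carry a different linker and acid portion from compound 1; no single-point step connects them to compound 1, so only the raw numbers speak.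

Compound 4, `CCO[C@@H](CC(=O)O)c1ccc(OCc2cccc(-c3c(C)cccc3C)c2)s1`, has not yet been measured in this assay. It differs from compound 1 in one place: 2-carboxy-1-ethoxyethyl in place of 2-carboxy-1-methoxyethyl on an aromatic carbon. The change adds one carbon in the alkoxy part of the acid-bearing side chain and brings one defined stereocentre where compound 1 has none.

Given that compound 1 gives 210 nM and the change is small, a step of at most modest size is expected, from compound 1 to compound 4 about a 1.4-fold lower number from compound 1 to compound 4 (0.15 log units; within the scatter), with the direction uncertain and likely within the scatter. Compound 4 is therefore expected to give about 150 nM, in the range 50 nM to 500 nM.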

Compound 4, half-maximal effective concentration: 40100 nM
Estimate against measurement, compound 4: 270-fold (2.43 log units) below; measured number outside the range, above it.
By their numbers in this assay, from the lowest: compound 1; then compound 2; then compounds 3 and 4 (each within the scatter of the next).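

In this assay, the side chain on the aromatic carbon next to the ring sulfur turns out to be highly sensitive to a small change: 2-carboxy-1-ethoxyethyl in place of 2-carboxy-1-methoxyethyl gives a 190-fold higher number from compound 1 to compound 4 (2.28 log units; beyond the scatter) and removes the advantage held by compound 1. Within the data shown here, compound 2 and compound 3 differ from compound 1 in more than one place, so this is the first one-place reading of this side chain. The step combines two differences, the ethoxy part and the defined stereocentre of compound 4, and nothing available separates their contributions or explains the size of the step.

The mirror-image form of compound 4 and the separated stereoisomers of compound 1 would show whether the stereocentre or the ethoxy part accounts for the step. On these data alone, whether a hydroxy group, or a longer chain such as propoxy, in place of the alkoxy part would follow the same trend also remains open.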